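Solubility of a thiophene thioether in a fluorophenyl oxazolidinone series

The source may report more compounds than this note shows. Statements on the series, on what has been measured and on what is new or still open speak of the compounds shown alone.

Measured compounds:
Compound 1 `O=C1O[C@@H](CO)CN1c1ccc(-n2cc(-c3ccccn3)cn2)c(F)c1` — 56400 nM
Compound 2 `CN1CCN(C[C@H]2CN(c3ccc(-n4cc(-c5ccccn5)cn4)c(F)c3)C(=O)O2)CC1` — 1690000 nM
Compound 3 `CC(=O)OC[C@H]1CN(c2ccc(-n3cc(-c4ccccn4)cn3)c(F)c2)C(=O)O1` — 373000 nM

In a physicochemical assay for solubility, read by HPLC, with a stated time of 24 h (a lower number here means a less soluble compound, a higher number a more soluble compound), compound 3 stands second highest of the three numbers, with compound 2 giving the highest value and compound 1 the lowest. The step of a 6.6-fold higher number from compound 1 to compound 3 (0.82 log units; beyond the scatter) was modest, and the step of a 4.5-fold lower number from compound 2 to compound 3 (0.66 log units; beyond the scatter) was also modest, while a 30-fold higher number from compound 1 to compound 2 (1.48 log units; beyond the scatter) was large.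

Compound 4 `O=C1O[C@@H](CSc2cccs2)CN1c1ccc(-n2cc(-c3ccccn3)cn2)c(F)c1` differs from compound 3 in one place: (thiophen-2-yl)sulfanyl in place of acetoxy on a saturated chain carbon bound to a saturated ring carbon. Among the compounds with values here, no measured step exchanges an acetoxy for a sulfanyl-linked aromatic ring, so none bears directly on it. The two steps that touch the same position, a 6.6-fold higher number from compound 1 to compound 3 (0.82 log units; beyond the scatter) and a 4.5-fold lower number from compound 2 to compound 3 (0.66 log units; beyond the scatter), show that this position moves the number by modest amounts in either direction. Compound 4 is expected to give a lower number than compound 3, with an estimated step of a 4.1-fold lower number from compound 3 to compound 4 (0.62 log units; beyond the scatter), since its change adds a second ring and no hydrogen-bond donor. Compound 4 is therefore estimated at 90000 nM, with a range from 25000 nM to 300000 nM.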

Compound 4, solubility: 8500 nM
For compound 4 the middle estimate is 11-fold (1.02 log units) above the measured one; the measured number lies below the stated range.
By their numbers in this assay, from the lowest: compound 4; then compound 1; then compound 3; then compound 2.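

In (this assay), the (thiophen-2-yl)sulfanyl group on the saturated chain carbon bound to a saturated ring carbon gives compound 4 the lowest number of the four, and it is the first group shown to fall below hydroxy (a 6.6-fold lower number from compound 1 to compound 4 (0.82 log units; beyond the scatter)). The position therefore moves the number down as well as up from hydroxy, and the span across it widens to a large step from the 4-methylpiperazin-1-yl compound (a 200-fold lower number from compound 2 to compound 4 (2.30 log units; beyond the scatter)), while the step from acetoxy is also large, not modest (a 44-fold lower number from compound 3 to compound 4 (1.64 log units; beyond the scatter)). No measured evidence accounts for this drop.

The compounds shown do not separate the sulfur link from the thiophene ring. A phenylsulfanyl, methylsulfanyl or thiophen-2-yloxy group at this position would tell which part goes with the lower number.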